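A few compounds are considered here, and "the series" means these few. Any claim that something is new, unique, unknown or untested is made for them only; others in the source may bear on it.

Compound 1 `COC(=O)C1(c2ccc(NC(=O)Nc3cccnc3Oc3ccccc3C(C)(C)C)cc2)CC1` gives 1 ug/mL
Compound 2 `CN(C)Cc1ccc(NC(=O)Nc2cccnc2Oc2ccccc2C(C)(C)C)c(F)c1` gives 160 ug/mL
Compound 3 `CC(C)CCN1CCC(COc2ccc(NC(=O)Nc3cccnc3Oc3ccccc3C(C)(C)C)c(F)c2)CC1` gives 87 ug/mL

In a physicochemical assay for solubility, in phosphate buffer, at pH 6.5 (on this read-out lower numbers stand for lower solubility and higher numbers for higher solubility), compound 1 stands lowest of the three, with its 1 ug/mL well beyond the scatter from both other compounds. The next structure, compound 4 `CC(C)CN1CCC(COc2ccc(NC(=O)Nc3cccnc3Oc3ccccc3C(C)(C)C)cc2)CC1`, keeps the core of compound 1 but changes one group: (1-isobutylpiperidin-4-yl)methoxy takes the place of 1-(methoxycarbonyl)cyclopropyl on an aromatic carbon. The counted difference is (1-isobutylpiperidin-4-yl)methoxy in place of 1-(methoxycarbonyl)cyclopropyl on an aromatic carbon and it is the whole change.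

Going by the values given here, no two measured compounds differ in one place only, so no measured step can serve as a direct guide. The nearest evidence is compound 3 at 87 ug/mL as it carries a closely similar group, though its structure also differs from compound 4 elsewhere. An upward move beyond the scatter is therefore expected, and the estimated step is a 60-fold higher number from compound 1 to compound 4 (1.78 log units; beyond the scatter) in this comparison. For compound 4 the estimate is 60 ug/mL with an expected range from 15 ug/mL to 200 ug/mL in this read-out.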

Compound 4, solubility: 27 ug/mL
Beside the measured number, compound 4's estimate is 2.2-fold (0.35 log units) above it; the measured number falls inside the stated range.
By their numbers in this assay, from the lowest: compound 1; then compound 4; then compounds 3 and 2 (each within the scatter of the next).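

In this assay, going by these compounds alone, this is the first comparison on the shared core in which only one place differs: on an aromatic carbon para to a large group, (1-isobutylpiperidin-4-yl)methoxy replaces 1-(methoxycarbonyl)cyclopropyl, giving a large step (a 27-fold higher number from compound 1 to compound 4 (1.43 log units; beyond the scatter)). Within the data shown here, the read-out therefore clearly responds to the group at this position, which the earlier compounds could not show, as each differed from the others in more than one place. Nothing measured here explains the size of this step.

The whole group changes at once, so it stays open which part of the entering group, such as the piperidine ring, its isobutyl chain or the ether oxygen, accounts for the step. As far as these compounds go, it is also open whether a carboxylic acid or a morpholine ring at this position would move the number as far.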